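Tetrazole on an Open Chain Replaces a Cyclopentyl Acid

The source may report more compounds than this note shows. Statements on the series, on what has been measured and on what is new or still open speak of the compounds shown alone.

Compound 1 `O=C(O)CC1CCCC1Cc1ccc(OCc2ccc3ccccc3n2)cc1` gives 100 nM in an assay on membranes from lung (Cavia porcellus) for binding affinity to cysteinyl leukotriene receptor (Homo sapiens) (on this read-out lower numbers stand for stronger inhibition and higher numbers for weaker inhibition), the highest number among the three measured compounds. Compound 3 `c1ccc2nc(COc3ccc(OCCCc4nnn[nH]4)cc3)ccc2c1` gives 69 nM in this assay, close to compound 1 and within the scatter. Compound 2 `c1ccc2nc(COc3ccc(CC4CCCC4Cc4nnn[nH]4)cc3)ccc2c1` gives 15 nM, and the step of a 6.7-fold lower number from compound 1 to compound 2 (0.82 log units; beyond the scatter) is the one that bears on the new compound. Compound 4 `CC(CCc1ccc(OCc2ccc3ccccc3n2)cc1)Cc1nnn[nH]1` differs from compound 1 by 2-((1H-tetrazol-5-yl)methyl)propyl in place of 2-(carboxymethyl)cyclopentyl on a saturated chain carbon bound to an aromatic carbon. It carries the same 1H-tetrazol-5-yl as compound 2 but on a 2-((1H-tetrazol-5-yl)methyl)propyl chain rather than a ring, and compound 3, also an open-chain tetrazole, sits closer to compound 1 than compound 2 does. A gain smaller than the measured step is therefore expected. Compound 4 is estimated at 30 nM, from 10 nM to 90 nM, a step of a 3.3-fold lower number from compound 1 to compound 4 (0.52 log units; beyond the scatter).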

Compound 4, inhibition constant: 25 nM
Compound 4: the middle estimate sits 1.2-fold (0.08 log units) above what was measured, within the range that was stated.
By their numbers in this assay, from the lowest: compounds 2 and 4 (each within the scatter of the next); then compounds 3 and 1 (each within the scatter of the next).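

The change gives a 4.0-fold lower number from compound 1 to compound 4 (0.60 log units; beyond the scatter) in this assay, so the lower number does not require the cyclopentyl ring: the open 2-((1H-tetrazol-5-yl)methyl)propyl chain also gives it, as the ring-bearing tetrazole did in a 6.7-fold lower number from compound 1 to compound 2 (0.82 log units; beyond the scatter). No measurement available here explains this gain. In this step the ring and the acid leave together, and the compounds shown do not separate their contributions. Going by these compounds, a carboxylic acid on the same open chain, or a longer chain carrying the 1H-tetrazol-5-yl, remains open.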